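A few compounds are considered here, and "the series" means these few. Any claim that something is new, unique, unknown or untested is made for them only; others in the source may bear on it.

Measured compounds:
compound 1 `CC(C)c1ccc(-c2nc(SCc3cn(CC(=O)NC(=O)Nc4ccccn4)nn3)nc(Nc3cccc(Cl)c3)c2C#N)cc1`: 1130 nM
compound 2 `Cc1ccc(Nc2nc(SCc3cn(CC(=O)NC(=O)Nc4ccccn4)nn3)nc(-c3ccc(C(C)C)cc3)c2C#N)cc1`: 3060 nM

Both numbers come from a functional assay on B16-F10 cells (Mus musculus) for inhibition, read by MTT assay, with a stated time of 72 h; on this read-out lower numbers stand for stronger inhibition and higher numbers for weaker inhibition. Among the compounds with values here, compound 2 stands highest of the two; the only other compound, compound 1, sits a 2.7-fold higher number from compound 1 to compound 2 (0.43 log units; beyond the scatter) away, so compound 2 marks the weak end of what has been measured so far. The next compound, compound 3 `COc1ccccc1Nc1nc(SCc2cn(CC(=O)NC(=O)Nc3ccccn3)nn2)nc(-c2ccc(C(C)C)cc2)c1C#N`, differs from compound 2 in one place: 2-methoxyphenyl in place of 4-methylphenyl on a nitrogen on an aromatic ring. Within the data shown here, the one measured step at this same nitrogen, a 2.7-fold higher number from compound 1 to compound 2 (0.43 log units; beyond the scatter), exchanged one substituted phenyl for another and moved the number modestly; it involved no methoxy group and so offers only a loose guide to the present change. The step to compound 3 is expected to be a 1.4-fold lower number from compound 2 to compound 3 (0.14 log units; within the scatter), a shift within or just beyond the scatter, with no firm direction. The estimate for compound 3 is 2200 nM, in the range 700 nM to 7000 nM.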

Compound 3, half-maximal inhibitory concentration: 34600 nM
The estimate for compound 3 lay 16-fold (1.20 log units) below the measured number; the whole stated range lies below it.
By their numbers in this assay, from the lowest: compound 1; then compound 2; then compound 3.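

In this assay the group on this nitrogen on an aromatic ring turns out to matter far more than the first exchange there suggested: the modest 2.7-fold higher number from compound 1 to compound 2 (0.43 log units; beyond the scatter) is followed by the large 11-fold higher number from compound 2 to compound 3 (1.05 log units; beyond the scatter) when 2-methoxyphenyl replaces 4-methylphenyl. Set against the 3-chlorophenyl group, the same 2-methoxyphenyl group gives a 31-fold higher number from compound 1 to compound 3 (1.49 log units; beyond the scatter) and leaves compound 3 at the weak end of the three, so a change of substituted phenyl alone can move the number by a wide margin. No measurement available here accounts for the size of these steps.

The compounds shown leave open whether the loss goes with the methoxy group itself or with where it sits on the phenyl ring, since none carries that group elsewhere on the ring. They also leave open how a hydroxyl, an amine or a longer ethoxy chain would behave on that ring.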